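Compound 4: one swap on a well-tolerated series

A few compounds are considered here, and "the series" means these few. Any claim that something is new, unique, unknown or untested is made for them only; others in the source may bear on it.

Measured in an ADME assay on THP-1 cells (Homo sapiens) for cytotoxicity; a lower number here means that less compound is tolerated, a higher number that more compound is tolerated:
Compound 1 `COc1ccc(NC(=O)c2ccsc2NC(=O)C(F)(F)F)cc1`: > 50000 nM, a limit
Compound 2 `COc1ccc(CNC(=O)c2c(NC(=O)C(F)(F)F)sc3c2CCCCC3)cc1`: > 50000 nM, a limit
Compound 3 `COc1ccc(NC(=O)c2c(NC(=O)C(F)(F)F)sc3c2CCC3)cc1`: > 50000 nM, a limit

None of these three entries is a true number, so the compounds cannot be ranked against one another. Compound 2, the starting point here, gives only a limit, > 50000 nM. It stands with the other two compounds at the limit of > 50000 nM in this assay, at which 3 of the 3 values shown sit.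

Compound 4 `Cc1ccc(NC(=O)c2c(NC(=O)C(F)(F)F)sc3c2CCCCC3)cc1` differs from compound 2 in one place, with 4-methylphenyl in place of 4-methoxybenzyl on an amide-type nitrogen. Within the data shown here, no two measured compounds differ in just one place, so no measured step shows what a swap of this kind does in this assay. Among the measured compounds shown here, the only guide is the shared behaviour of the compounds already tested.

The expected step of a number no higher from compound 2 to compound 4 (the limit leaves the size open) is none beyond the usual scatter, and no direction is favoured. This expectation rests on compound 2 and on (the limit of > 50000 nM in this assay, at which 3 of the 3 values shown sit). Compound 4 may well return only a limit too. If it gives a real number, the estimate for compound 4 is 50000 nM, with an expected range from 20000 nM to 100000 nM.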

Compound 4, half-maximal cytotoxic concentration: > 50000 nM
Compound 4 ended at the assay's limit (the forecaster's own chance of this, stated with the estimate: 65%); the middle value sits exactly at the limit.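

In this assay compound 4 gives > 50000 nM, which is a limit. Among these compounds, compound 2 also gives only a limit, and no step from compound 2 to compound 4 can be read. The compounds shown leave open at what concentration any of them harms these cells, and whether 4-methylphenyl and 4-methoxybenzyl differ at all here.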